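From a Dimethylamino Chain to a Hydroxy Chain

The compounds below may be only part of what the source reports. "The series", "measured", "known", "first", "only" and "open" are said of these compounds alone.

In a functional assay (trachea) with Cavia porcellus as the target (a lower number here means that less compound is needed, a higher number that more compound is needed for the effect), compound 1 (`CCCn1cnc2c1c(=O)n(C)c(=O)n2CCC`) gives 5000 nM. Compound 2 (`CCCn1c(=O)n(C)c(=O)c2c1ncn2CCN(C)C`) gives > 100000 nM, which is a limit of the assay and not a number. Compound 3 (`CCCn1c(=O)n(C)c(=O)c2c1ncn2CCCN(C)C`) gives > 100000 nM, which is likewise only a limit. Compound 3 therefore has no measured number, and the data show a step that the two limits leave unreadable from compound 2 to compound 3.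

In compound 4 (`CCCn1c(=O)n(C)c(=O)c2c1ncn2CCO`), hydroxy stands in place of (dimethylamino)methyl on a saturated chain carbon, two bonds along the chain from an aromatic nitrogen: hydroxy in place of (dimethylamino)methyl on a saturated chain carbon, two bonds along the chain from an aromatic nitrogen. Going by the values given here, no measured step makes this exact change. The nearest evidence is an at least 20-fold higher number from compound 1 to compound 2 (1.30 log units; beyond the scatter) and an at least 20-fold higher number from compound 1 to compound 3 (1.30 log units; beyond the scatter), both large and both introducing dimethylamino. Removing that group is thus expected to give a lower number in this assay, though hydroxy may not return the value fully to that of compound 1. The expected change is an at least 4.0-fold lower number from compound 3 to compound 4 (0.60 log units; beyond the scatter). Compound 4 is estimated at 25000 nM, with an expected range from 6000 nM to 100000 nM.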

Compound 4, half-maximal effective concentration: 31800 nM
Beside the measured number, compound 4's estimate is 1.3-fold (0.10 log units) below it; the measured number falls inside the stated range.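

In this assay, hydroxy in place of the amine ends of the chains gives an at least 3.1-fold lower number from compound 3 to compound 4 (0.49 log units; beyond the scatter) and an at least 3.1-fold lower number from compound 2 to compound 4 (0.49 log units; beyond the scatter), and both steps rest on a limit of the assay and not on a number for the amine compound: the limit of > 100000 nM in this assay, at which 2 of the 4 values shown sit.

Hydroxy does not bring the chain back to the plain propyl of compound 1, since there remains a 6.4-fold higher number from compound 1 to compound 4 (0.80 log units; beyond the scatter). The higher number at this position is thus not tied to dimethylamino alone: compound 4 carries no amine and still needs more compound than compound 1.

On these data alone, whether a methoxy or a carboxylic acid at the end of the chain would behave like hydroxy stays open. So does the effect of chain length with hydroxy in place, as in a longer 3-hydroxypropyl chain.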